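The source may hold more compounds than are shown below. What is called first, only, known or untested is meant among the compounds shown, and "the series" means these compounds.

Measured compounds:

Compound 1, `CC(=O)Nc1ccc(OC(=S)Nc2ccc(Oc3ccc(C(F)(F)F)cc3)cc2)cc1`, in a physicochemical assay for acid dissociation, compound 1 gives 9.03.

Compound 2, `O=[N+]([O-])c1ccc(Oc2ccc(NC(=S)Oc3ccc(O)cc3)cc2)cc1`, in this assay compound 2 gives 9.23.

Of the two numbers, compound 2 has the higher one, and its nearest neighbour is compound 1, which lies lower by an amount that falls within the scatter of repeated measurements. The two compounds therefore cannot be told apart on these numbers.

Compound 3, `Oc1ccc(OC(=S)Nc2ccc(Oc3ccc(C(Cl)(Cl)Cl)cc3)cc2)cc1`, has not yet been measured. It differs from compound 2 as follows: trichloromethyl in place of nitro on an aromatic carbon. The group that leaves and the group that enters both sit far from the part of the shared core that carries the proton in question. For the measured compounds named here, no step between measured compounds with a change of this kind is known here. The expected step from compound 2 to compound 3 in this assay is therefore small, a number 0.07 log units higher from compound 2 to compound 3 (within the scatter), and may amount to nothing beyond the scatter. Compound 3 is expected to give about 9.3, somewhere between 8.9 and 9.7.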

Compound 3, acid dissociation constant: 9.24
The estimate for compound 3 lay 0.06 log units above the measured number; the measured number falls inside the stated range.
By their numbers in this assay, from the lowest: compounds 1, 2 and 3 (each within the scatter of the next).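

In this assay, swapping the nitro group for trichloromethyl, at a site on an aromatic carbon para to a large group, gives a number 0.01 log units higher from compound 2 to compound 3 (within the scatter). For the compounds shown here, compounds 1 and 2 differ in more than one place, so this is the only single change that can be read here, and it shows that exchanging a group of nitrogen and oxygen for one of carbon and chlorine at this position leaves a number that cannot be told apart from that of compound 2. Nothing given here explains this outcome.

One exchange says little about the position as a whole. From the compounds shown here alone, whether an amine, a carboxylic acid or a longer chain in the same place would also stay within the scatter remains open, as does whether the same exchange would behave alike with other changes elsewhere on the shared core.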